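A few compounds are considered here, and "the series" means these few. Any claim that something is new, unique, unknown or untested is made for them only; others in the source may bear on it.

In an ADME assay on BJ cells (Homo sapiens) for cytotoxicity, with a stated time of 72 h (on this read-out higher numbers stand for an effect only at larger amounts of compound and lower numbers for an effect already at smaller amounts), compound 1 `Nc1nc(-c2ccc(Cl)cc2)nn1-c1ncnc2cc(Cl)ccc12` gives > 47000 nM, which is a limit of the assay and not a number. Compound 2 `Nc1cc2c(-n3nc(-c4ccccn4)nc3N)ncnc2cc1Cl` gives 27000 nM, a true reading. These two compounds therefore show an effect only at large amounts. Compound 3 `COc1cc2ncnc(-n3nc(-c4ccncc4)nc3N)c2cc1OC`, the starting point of this step, has no number to stand on: its entry in this assay reads "not determined" (no result reported). Its place on the scale is therefore unknown, and only its neighbours offer any guidance.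

Compound 4 `COc1cc2ncnc(-n3nc(-c4ccc(Cl)cc4)nc3N)c2cc1OC` has not yet been measured. The step 4-chlorophenyl in place of pyridin-4-yl on an aromatic carbon puts 4-chlorophenyl in place of pyridin-4-yl on an aromatic carbon of the five-membered ring. Among the compounds with values here, no measured pair of compounds shows what this kind of change does, so the size of the step cannot be read from the data. Within the data shown here, with no step to go on, the expectation is for no shift beyond the usual scatter, in either direction. Compound 1 also carries 4-chlorophenyl, on a core of its own, and its > 47000 nM is again a limit. A reading for compound 4 may therefore also end up as a limit. Compound 4 is expected at about 35000 nM, with an estimated range of 13000 nM to 70000 nM.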

Compound 4, half-maximal effective concentration: > 50000 nM
Compound 4: a limit, no number (the forecaster's own chance of this, stated with the estimate: 50%); middle value at least 1.4-fold (0.15 log units) from the limit.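

Within the data shown here, compound 3 has no number in this assay, so no step from compound 3 to compound 4 can be read. Compound 4 gives > 50000 nM, which is a limit and not a number. The compounds shown leave open how far 4-chlorophenyl in place of pyridin-4-yl shifts this read-out on the shared core, or in which direction.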